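This account rests on a few compounds, and the source may have more. Where it says the series, first, only, none or still open, it means among the compounds named here.

Compound 1 `COc1cc(-c2nccn3cc(-c4ccc(F)cc4)nc23)cc(OC)c1OC` gives 137 nM in a functional assay on A549 cells (Homo sapiens) for inhibition, read by MTT assay, with a stated time of 48 h (a lower number here means a stronger inhibitor, a higher number a weaker inhibitor), the lowest of the numbers shown; nearest is compound 2 `COc1cc(-c2nccn3cc(-c4ccc(Cl)cc4)nc23)cc(OC)c1OC`, which in this assay gives 7290 nM. Compound 3 `COc1cc(-c2nccn3cc(-c4ccc([N+](=O)[O-])cc4)nc23)cc(OC)c1OC` reports only a limit of this assay, > 10000 nM (the limit of > 10000 nM in this assay, at which 1 of the 3 values shown sits).

Compound 4 `COc1cc(-c2nccn3cc(-c4ccc(N)cc4)nc23)cc(OC)c1OC` differs from compound 1 by amino in place of fluoro on an aromatic carbon. Going by the values given here, two measured steps bear on this change, each a replacement of the same fluoro: a 53-fold higher number from compound 1 to compound 2 (1.73 log units; beyond the scatter) and an at least 72-fold higher number from compound 1 to compound 3 (1.86 log units; beyond the scatter). Both were large rises, and between them an at least 1.3-fold higher number from compound 2 to compound 3 (0.13 log units; that floor lies within the scatter) adds little. Amino has no measured precedent in the series, so a rise in this assay of comparable direction is expected, with wide uncertainty. Compound 4 is expected near 3000 nM, between 400 nM and 15000 nM. Compound 4 is thus expected to show a 22-fold higher number from compound 1 to compound 4 (1.34 log units; beyond the scatter).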

Compound 4, half-maximal inhibitory concentration: 287 nM
Estimate against measurement, compound 4: 10-fold (1.02 log units) above; the whole stated range lies above it.
By their numbers in this assay, from the lowest: compound 1; then compound 4; then compound 2. At a limit, above all of these: compound 3.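

In this assay, going by these compounds alone, fluoro is not the only group at this position that keeps the number low: amino gives only a 2.1-fold higher number from compound 1 to compound 4 (0.32 log units; beyond the scatter), a modest step. Chloro does not share this, with a 25-fold lower number from compound 2 to compound 4 (1.40 log units; beyond the scatter) marking a large separation from amino. The nitro compound stands at a limit of the assay, so an at least 34-fold lower number from compound 3 to compound 4 (1.54 log units; beyond the scatter) is only a floor: the limit of > 10000 nM in this assay, at which 1 of the 4 values shown sits.

Going by these compounds, whether a hydroxyl, a methoxy or a methyl at this position would stay near compound 1 remains open. Also open, on these data alone, is whether an acetamide or dimethylamino group would keep the level of compound 4.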